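The compounds below may be only part of what the source reports. "The series", "measured", "known", "first", "only" and "open" are said of these compounds alone.

Measured in a functional assay on HCT-116 cells (Homo sapiens) for antiproliferative activity, read by sulforhodamine B assay, with a stated time of 72 h; a higher number here means a weaker inhibitor, a lower number a stronger inhibitor:
- compound 1 `Cn1ncc(Cl)c1-c1cc(C(=O)N[C@@H]2CN[C@H](CCCO)C[C@H]2c2ccc(Cl)c(Cl)c2)oc1Cl`: 510 nM
- compound 2 `Cn1ncc(Cl)c1-c1cc(C(=O)N[C@@H]2CN[C@H](CCn3cncn3)C[C@H]2c2ccc(Cl)c(Cl)c2)oc1Cl`: 560 nM
- compound 3 `CC(=O)NCC[C@@H]1C[C@@H](c2ccc(F)c(F)c2)[C@H](NC(=O)c2cc(-c3c(Cl)cnn3C)c(Cl)o2)CN1`: 920 nM

Compound 2, at 560 nM, lies within the scatter of both compound 1 and compound 3, so these three numbers cannot be told apart.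

The compound still to be measured is compound 4 `CN(C)CC[C@@H]1C[C@@H](c2ccc(Cl)c(Cl)c2)[C@H](NC(=O)c2cc(-c3c(Cl)cnn3C)c(Cl)o2)CN1`. Its difference from compound 2 is dimethylamino in place of 1H-1,2,4-triazol-1-yl on a saturated chain carbon, two bonds along the chain from a saturated ring carbon. In words, it carries dimethylamino in place of 1H-1,2,4-triazol-1-yl on a saturated chain carbon, two bonds along the chain from a saturated ring carbon.

Within the data shown here, one measured step bears on this place: a 1.1-fold higher number from compound 1 to compound 2 (0.04 log units; within the scatter). That step brought in the 1H-1,2,4-triazol-1-yl group in place of hydroxymethyl and stayed within the scatter. Compound 3, at 920 nM, differs from compound 2 in more than one place, so it gives only a general sense of the range. Among the measured compounds shown here, no measured compound yet carries dimethylamino, which leaves the expectation resting on that single small step. In this assay, no step beyond the scatter is therefore expected, and no direction can be favoured.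

The estimate amounts to a 1.1-fold lower number from compound 2 to compound 4 (0.03 log units; within the scatter), which is expected to stay within the scatter. For compound 4 the estimated value is 520 nM, with an expected range of 230 nM to 1150 nM.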

Compound 4, half-maximal inhibitory concentration: 1710 nM
Compound 4: middle estimate off by 3.3-fold (0.52 log units), on the low side, and the stated range ends below it.
By their numbers in this assay, from the lowest: compounds 1, 2, 3 and 4 (each within the scatter of the next, the first and the last beyond it).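

In this assay, the swap of hydroxymethyl for 1H-1,2,4-triazol-1-yl had left the number within the scatter, so this place on the chain could have seemed indifferent to the group it carries. Dimethylamino shows that it is not: it gives a 3.1-fold higher number from compound 2 to compound 4 (0.48 log units; beyond the scatter) and, against the hydroxymethyl-bearing compound, a 3.4-fold higher number from compound 1 to compound 4 (0.53 log units; beyond the scatter). Both steps are modest, but they are the only ones at this place that lie beyond the scatter, and they run in the same direction, towards a weaker inhibitor, whichever of the two groups dimethylamino replaces. The data shown offer no measurement that would explain this difference.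

The compounds shown leave open whether the weakening belongs to amines at this place in general or to dimethylamino alone, a question that a primary amine, a methylamino group or a morpholine on the same chain would address. They also leave open how a longer or shorter chain carrying dimethylamino would read in this assay.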